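Chloro to fluoro next to the ring nitrogen

The source may report more compounds than this note shows. Statements on the series, on what has been measured and on what is new or still open speak of the compounds shown alone.

In an in vitro functional assay on 1321-N1 cells for agonist activity at Free fatty acid receptor 1 (Homo sapiens), read by fluorescence, spectrophotometry and calcium flux (on this read-out higher numbers stand for larger maximal responses and lower numbers for smaller maximal responses), compound 1 `O=C(O)CCc1ccc(C#Cc2ccnc(F)c2)cc1` gives 98%. Compound 2 `Cc1c(C#Cc2ccc(CCC(=O)O)cc2)ccnc1Cl` gives 101% in this assay, the upper of the two numbers shown, though compound 1 sits within the scatter of it, so the two are not separated. Compound 3 `Cc1c(C#Cc2ccc(CCC(=O)O)cc2)ccnc1F` awaits measurement in this assay; it differs from compound 2 by fluoro in place of chloro on an aromatic carbon. Among the measured compounds shown here, no measured pair covers this change, and with both known numbers near the full reference response no step beyond the scatter is expected in either direction. For compound 3 the estimate in this assay is 98%, within 88% to 106%. This corresponds to an expected a number 3 percentage points lower from compound 2 to compound 3 (within the scatter).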

Compound 3, largest response reached (reported as efficacy), in percent of the reference or control that the assay uses: 101%
Beside the measured number, compound 3's estimate is 3 percentage points below it, within the range that was stated.
By their numbers in this assay, from the lowest: compounds 1, 2 and 3 (each within the scatter of the next).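

In this assay, fluoro in place of chloro next to the ring nitrogen gives no change at the digits printed from compound 2 to compound 3 (within the scatter), so this pair does not separate the two halogens on maximal response. With fluoro kept, methyl in place of hydrogen on an aromatic carbon gives a number 3 percentage points higher from compound 1 to compound 3 (within the scatter), so the methyl group does not separate that pair either. Nothing available bears on a cause for these results. Maximal response alone leaves potency open. Also open, on these data alone, is whether a methoxy group or an amine next to the ring nitrogen would give a similar maximal response.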